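Piperidin-1-yl in place of piperazin-1-yl on the shared core

A few compounds are considered here, and "the series" means these few. Any claim that something is new, unique, unknown or untested is made for them only; others in the source may bear on it.

Within the data shown here, in a functional assay on KB cells (Homo sapiens) for antiproliferative activity, read by MTT assay (on this read-out higher numbers stand for weaker inhibition and lower numbers for stronger inhibition), compound 1 `c1ccc2c(c1)ccn2-c1nc(N2CCNCC2)nc2ccccc12` gives 4 ug/mL as the lowest of the three numbers so far. Compound 2 `c1ccc(N2CCN(c3nc(-n4ccc5ccccc54)c4ccccc4n3)CC2)cc1` gives 50 ug/mL and compound 3 `COc1cc(OC)c(-c2nc(N3CCN(C)CC3)nc3ccccc23)c(OC)c1` gives 50 ug/mL on the same read-out. Compound 4 `c1ccc2c(c1)ccn2-c1nc(N2CCCCC2)nc2ccccc12` keeps the core of compound 1 and carries piperidin-1-yl in place of piperazin-1-yl on an aromatic carbon. Among the measured compounds shown here, the one measured step that bears on this change is phenyl in place of hydrogen on an amine nitrogen in a ring, and it is large. For the measured compounds named here, compound 3 has no measured step to the others and adds nothing here. Compound 4 also loses that amine hydrogen without gaining phenyl, so a higher number is expected, though a smaller step than a 13-fold higher number from compound 1 to compound 2 (1.10 log units; beyond the scatter) in size. The expected step in this assay is a 3.8-fold higher number from compound 1 to compound 4 (0.57 log units; beyond the scatter) as an estimate only. For compound 4 the estimated value is 15 ug/mL with an expected range from 5 ug/mL to 50 ug/mL on this read-out.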

Compound 4, half-maximal inhibitory concentration: 50 ug/mL
Compound 4: the middle estimate sits 3.3-fold (0.52 log units) below what was measured; the measured number falls inside the stated range.
By their numbers in this assay, from the lowest: compound 1; then compounds 2, 3 and 4 (each within the scatter of the next).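

In this assay, the position between two ring nitrogen atoms does not tolerate the loss of the second ring nitrogen with its hydrogen: piperidin-1-yl in place of piperazin-1-yl gives a 13-fold higher number from compound 1 to compound 4 (1.10 log units; beyond the scatter). Until now, the only step at this group was a change on the ring amine nitrogen, a 13-fold higher number from compound 1 to compound 2 (1.10 log units; beyond the scatter), which kept that nitrogen; the new step is also large, so removing the nitrogen outright gives no recovery, and on the shared core only compound 1 keeps the amine hydrogen, with no compound shown going against this. No measurement at hand explains the step.

Still open, on these data alone, is whether the amine hydrogen or the ring nitrogen itself carries the difference. A methyl on the ring amine nitrogen, a morpholine ring or a 4-aminopiperidin-1-yl group on the core of compound 1 would bear on that.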